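Changing the amide chain of compound 3

This account rests on a few compounds, and the source may have more. Where it says the series, first, only, none or still open, it means among the compounds named here.

Three compounds have been measured so far in a functional assay on Caco-2 cells (Homo sapiens), read by MTT assay, with a stated time of 48 h (on this read-out higher numbers stand for weaker inhibition and lower numbers for stronger inhibition), and give these values:
- compound 1 `CCN(CC)CCNC(=O)c1ccc(C(CC)(CC)c2ccc(OCC(=O)C(C)(C)C)c(C)c2)n1CC` gives 1600 nM as a number
- compound 2 `CCN(CC)CCCNC(=O)c1ccc(C(CC)(CC)c2ccc(OCC(=O)C(C)(C)C)c(C)c2)n1CC` gives 1000 nM as a number
- compound 3 `CCn1c(C(=O)NCC(OC)OC)ccc1C(CC)(CC)c1ccc(OCC(O)C(C)(C)C)c(C)c1` gives > 50000 nM as a limit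

Compound 3 has no exact number, since > 50000 nM is a limit of the assay. Compound 3 therefore stands at the limit of > 50000 nM in this assay, at which 1 of the 3 values shown sits, and has no place on a measured scale.

Compound 4 `CC[C@@H](C)[C@H](NC(=O)c1ccc(C(CC)(CC)c2ccc(OCC(O)C(C)(C)C)c(C)c2)n1CC)C(=O)O` has 1-carboxy-2-methylbutyl in place of 2,2-dimethoxyethyl on an amide-type nitrogen and is otherwise the same as compound 3.

Going by the values given here, the only measured step that bears on this is a 1.6-fold lower number from compound 1 to compound 2 (0.20 log units; within the scatter) and it also changes a chain on an amide-type nitrogen. It is small, so a change at this place is expected to move the value little, and compound 4 may again report only a limit.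

The expected size of the change is a number no higher from compound 3 to compound 4 (the limit leaves the size open) and no shift beyond the scatter is expected. In this assay the estimate for compound 4 is 50000 nM with an expected range of 15000 nM to 100000 nM for a measured number.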

Compound 4, half-maximal inhibitory concentration: 3400 nM
Estimate against measurement, compound 4: 15-fold (1.17 log units) above, outside the stated range (below it).
By their numbers in this assay, from the lowest: compounds 2 and 1 (each within the scatter of the next); then compound 4. At a limit, above all of these: compound 3.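

Replacing 2,2-dimethoxyethyl with 1-carboxy-2-methylbutyl on the amide-type nitrogen gives, in this assay, an at least 14-fold lower number from compound 3 to compound 4 (1.16 log units; beyond the scatter). The chain at this place can therefore matter a great deal, which the earlier step, a 1.6-fold lower number from compound 1 to compound 2 (0.20 log units; within the scatter), gave no sign of. Compound 3 carries a limit of the assay rather than a number, so the size of the new step is only a minimum: the limit of > 50000 nM in this assay, at which 1 of the 4 values shown sits.

The entering chain differs from the leaving one in more than one way, so the compounds shown do not tell whether the carboxylic acid or the branched carbon chain accounts for the step. A methyl ester of the same chain, or an unbranched chain ending in a carboxylic acid, would be needed to separate the two.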